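Taking the carboxy group off a nitro compound

The compounds below may be only part of what the source reports. "The series", "measured", "known", "first", "only" and "open" are said of these compounds alone.

In a functional assay on HT-1080 cells (Homo sapiens) for antiproliferative activity, read by MTT assay, with a stated time of 72 h (a higher number here means a weaker inhibitor, a lower number a stronger inhibitor), compound 1 (`COc1ccc(-c2cc(C(=O)O)sc2-c2cc(OC)c(OC)c(OC)c2)cc1`) gives 5810 nM as its reading, while compound 2 (`COc1ccc(-c2cc(C(=O)O)sc2-c2cc(OC)c(OC)c(OC)c2)cc1[N+](=O)[O-]`) gives 38100 nM as the higher of the two numbers, which makes it the weaker inhibitor of the pair. The next compound, compound 3 (`COc1ccc(-c2ccsc2-c2cc(OC)c(OC)c(OC)c2)cc1[N+](=O)[O-]`), keeps the nitro group and differs at another place. The counted difference hydrogen in place of carboxy on an aromatic carbon amounts to hydrogen in place of carboxy on an aromatic carbon of a five-membered aromatic ring with 1 sulfur, next to the ring sulfur. Going by the values given here, the only measured step is a 6.6-fold higher number from compound 1 to compound 2 (0.82 log units; beyond the scatter) for nitro in place of hydrogen on an aromatic carbon. It involves no carboxy group and so offers only a sense of scale. Both measured compounds carry the carboxy group, so the data contain no direct test of its loss. Losing a whole carboxy group is expected to move the number at least as far as the nitro step did, and the expected direction, a judgment rather than a trend, is downward. The estimated change is a 64-fold lower number from compound 2 to compound 3 (1.80 log units; beyond the scatter) with wide uncertainty. For compound 3 the estimated value in this assay is 600 nM within an expected range of 25 nM to 10000 nM overall.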

Compound 3, half-maximal inhibitory concentration: 8040 nM
Compound 3: the middle estimate sits 13-fold (1.13 log units) below what was measured; the measured number falls inside the stated range.
By their numbers in this assay, from the lowest: compounds 1 and 3 (each within the scatter of the next); then compound 2.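

In this assay, going by these compounds alone, hydrogen in place of carboxy gives a 4.7-fold lower number from compound 2 to compound 3 (0.68 log units; beyond the scatter), the first reading at this position, on an aromatic carbon of a five-membered aromatic ring with 1 sulfur, next to the ring sulfur, since the two earlier compounds both carry the carboxy group. With the nitro group in place, the carboxy group is therefore not needed for the activity seen here, and its loss moves the number downward by an amount beyond the scatter, the opposite direction to the earlier step, a 6.6-fold higher number from compound 1 to compound 2 (0.82 log units; beyond the scatter). Nothing measured here offers an explanation for this change.

The compounds shown leave open whether the same step would appear in a compound without the nitro group, as this single pair tests the loss of carboxy only with nitro present. They also leave open whether a methyl ester, a primary amide or an aminomethyl group at this position would give a number closer to that of the carboxy group or to that of hydrogen.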